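This account rests on a few compounds, and the source may have more. Where it says the series, first, only, none or still open, it means among the compounds named here.

This set of compounds was tested for how strongly each one blocks a kinase enzyme, measured in an assay on isolated protein for inhibition of Leucine-rich repeat serine/threonine-protein kinase 2 (Homo sapiens), read by TR-FRET and LanthaScreen, with stated times of 50 min and 30 min, in the presence of a further agent that is not named here; on this read-out higher numbers stand for weaker inhibition and lower numbers for stronger inhibition. Compound 1 `Cc1nn(C2COC2)cc1Nc1nc(N)c2c(C#N)c(N3CCC[C@H]3C)n(C)c2n1` gives 38 nM. Compound 3 `Cc1nn(C2CCOC2)cc1Nc1nc(N)c2c(C#N)c(N3CCC[C@H]3C)n(C)c2n1` was run repeatedly and gives 19 nM; 44 nM (2 entries); the spread among the several entries of compound 3 in this assay, 19 nM; 44 nM (2 entries) shows how far repeated runs of one compound can drift. Compound 2 `Cc1cn(C)nc1Nc1cc2c(c(N)n1)c(C#N)c(N1CCC[C@H]1C)n2C` gives 2110 nM, the higher of the two single numbers here; its nearest neighbour on the scale is compound 1, whose number lies far lower, a gap well beyond the usual scatter.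

Compound 4 `C[C@@H]1CCCN1c1c(C#N)c2c(N)nc(Nc3ccn(C)n3)cc2n1C` has not yet been measured. It differs from compound 2 in one place only, (hydrogen in place of methyl on an aromatic carbon), that is, hydrogen in place of methyl on an aromatic carbon. For the measured compounds named here, no pair of measured compounds shows this same change, so there is no direct precedent for its size or direction. The expectation is for a small step, if any, probably not beyond the scatter and leaning towards a somewhat higher number than compound 2. Compound 4 is therefore estimated at 3000 nM, with a likely range from 1000 nM to 10000 nM. That estimate means a step of a 1.4-fold higher number from compound 2 to compound 4 (0.15 log units; within the scatter) in this assay.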

Compound 4, half-maximal inhibitory concentration: 234 nM
The estimate for compound 4 lay 13-fold (1.11 log units) above the measured number; measured number below the stated range.
By their numbers in this assay, from the lowest: compound 1; then compound 4; then compound 2.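

Taking the methyl group off the aromatic carbon of the five-membered ring, which turns 1,4-dimethyl-1H-pyrazol-3-yl into 1-methyl-1H-pyrazol-3-yl, gives a 9.0-fold lower number from compound 2 to compound 4 (0.96 log units; beyond the scatter) in this assay. For the compounds shown here, this carbon is therefore not a neutral spot: the loss of one heavy atom, with no ring, no net charge and no hydrogen-bond donor or acceptor involved, clearly shifts the number, and the shift is towards stronger inhibition, something no earlier pair could show. The step is also much wider than the drift seen when a single compound is simply run again: the several entries of compound 3 in this assay, 19 nM; 44 nM (2 entries)

On these data alone, with only methyl and hydrogen compared at this carbon, it remains open how a single fluorine atom, an ethyl group or a methoxy group would behave there, and whether any of them would give a lower number than hydrogen does. As far as these compounds go, the step also rests on one pair, so it remains open whether the same change would have a similar size or direction on a different core, such as the core of compound 1.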